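Methyl on the Ring Carbon, Carried onto the Piperidine Amide

The source may hold more compounds than are shown below. What is called first, only, known or untested is meant among the compounds shown, and "the series" means these compounds.

Compound 1 `N#C[C@@H]1CCCN1C(=O)[C@@H]1C[C@H](C(=O)N2CCOCC2)CN1` gives 73% in an assay on the whole organism (plasma, strain Sprague-Dawley) for inhibition of Dipeptidyl peptidase 4 (Rattus norvegicus), with a stated time of 6 h, at a dose of 1 mg/kg by the oral route; a lower number here means less inhibition, a higher number more inhibition at the dose given (going by the name of the read-out). Compound 2 `C[C@@H]1N[C@H](C(=O)N2CCC[C@H]2C#N)C[C@@H]1C(=O)N1CCOCC1` differs from it by methyl in place of hydrogen on a saturated ring carbon, and in this assay compound 2 gives 94%, a step of a number 21 percentage points higher from compound 1 to compound 2 (beyond the scatter). Compound 3 `N#C[C@@H]1CCCN1C(=O)[C@@H]1C[C@H](C(=O)N2CCCCC2)CN1` has a different core, set apart from compound 1 by piperidin-1-yl in place of morpholin-4-yl on a carbonyl carbon; in this assay compound 3 gives 84%, a step of a number 11 percentage points higher from compound 1 to compound 3 (beyond the scatter). Compound 4 `C[C@@H]1N[C@H](C(=O)N2CCC[C@H]2C#N)C[C@@H]1C(=O)N1CCCCC1` is not yet measured; it differs from compound 3 by methyl in place of hydrogen on a saturated ring carbon, the same change that leads from compound 1 to compound 2, now made on the core of compound 3. The number of compound 3 in this assay already stands high, so the room for a higher number is smaller. Compound 4 is nevertheless expected to rise, by a step estimated at a number 9 percentage points higher from compound 3 to compound 4 (within the scatter), because a number 21 percentage points higher from compound 1 to compound 2 (beyond the scatter) was seen from a lower starting point. Compound 4 is therefore expected to give about 93%, within 84% to 99%.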

Compound 4, a percentage reported as inhibition, in the whole organism at one dose (the size of the read-out at that dose, not a potency): 91%
Compound 4: the middle estimate sits 2 percentage points above what was measured; measured number inside the range.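

In this assay, methyl in place of hydrogen on a saturated ring carbon gives a number 7 percentage points higher from compound 3 to compound 4 (within the scatter), and this step cannot be told apart from the earlier one: the same change on two cores in this assay, a number 21 percentage points higher (beyond the scatter) from compound 1 to compound 2 and a number 7 percentage points higher (within the scatter) from compound 3 to compound 4, 14 percentage points apart, within the scatter of two such steps. With the methyl present, piperidin-1-yl in place of morpholin-4-yl on a carbonyl carbon gives a number 3 percentage points lower from compound 2 to compound 4 (within the scatter), and again the two steps cannot be told apart: the same change on two cores in this assay, a number 11 percentage points higher (beyond the scatter) from compound 1 to compound 3 and a number 3 percentage points lower (within the scatter) from compound 2 to compound 4, 14 percentage points apart, within the scatter of two such steps. The results fit the methyl change carrying over to the new core but do not prove it, since the new step itself lies within the scatter and the read-out comes from one dose, leaving little room near the top.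

The compounds shown leave open whether an ethyl group or a longer chain would serve on that ring carbon. They also leave open how a piperazin-1-yl amide, which carries a ring amine, would compare.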